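The source may hold more compounds than are shown below. What is called first, only, known or untested is meant among the compounds shown, and "the series" means these compounds.

Measured so far:
Compound 1 `O=C1C[C@H](O)C[C@@H](/C=C/c2c(Cl)cc(Cl)cc2-c2cc(Cl)cc(Cl)c2)O1`: 37 nM
Compound 2 `Cc1cc(-c2cc(Cl)cc(C)c2/C=C/[C@@H]2C[C@@H](O)CC(=O)O2)ccc1F`: 6 nM
Compound 3 `Cc1cc(C)c(/C=C/[C@@H]2C[C@@H](O)CC(=O)O2)c(-c2ccc(F)cc2)c1`: 13 nM

In an assay for inhibition of 3-hydroxy-3-methylglutaryl-coenzyme A reductase (Rattus norvegicus) (on this read-out higher numbers stand for weaker inhibition and lower numbers for stronger inhibition), compound 1 gives the highest number of the three, 37 nM. Compound 3, the nearest to it, gives 13 nM, a lower number by a margin beyond the usual scatter of this assay, and compound 2 lies furthest away with 6 nM, also beyond the scatter. Compound 1 is therefore the weakest inhibitor of the three measured compounds.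

The unmeasured compound 4 `O=C1C[C@H](O)C[C@@H](/C=C/c2c(Cl)cc(Cl)cc2-c2cccc(F)c2)O1` differs from compound 1 in one place: 3-fluorophenyl in place of 3,5-dichlorophenyl on an aromatic carbon. For the measured compounds named here, no step between measured compounds tracks this change directly. Compounds 2 and 3 both carry a fluorophenyl group, though each on a different core, and both give lower numbers than compound 1 in this assay; they offer only an indirect hint for compound 4.

On that basis compound 4 is expected to give a somewhat lower number than compound 1, a step of a 1.9-fold lower number from compound 1 to compound 4 (0.27 log units; within the scatter) that may or may not clear the scatter. The estimate for compound 4 is 20 nM, with a range from 6 nM to 60 nM.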

Compound 4, half-maximal inhibitory concentration: 70 nM
Compound 4: the middle estimate sits 3.5-fold (0.54 log units) below what was measured, outside the stated range (above it).
By their numbers in this assay, from the lowest: compound 2; then compound 3; then compounds 1 and 4 (each within the scatter of the next).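

In this assay, for the compounds shown here, 3-fluorophenyl in place of 3,5-dichlorophenyl gives a 1.9-fold higher number from compound 1 to compound 4 (0.28 log units; within the scatter), the first direct reading of any change at this position. Compound 1 and compound 4 therefore cannot be told apart on this read-out: on this core, the two chlorines of the ring can give way to a single fluorine, with one heavy atom fewer in the group, without a shift beyond the usual scatter. This holds for this one pair only, and nothing in the data shown accounts for how closely the two groups read.

The compounds shown leave open how a plain phenyl, a 3-chlorophenyl, or a phenyl ring carrying an amine or a carboxylic acid would read at this position, so the separate contributions of the chlorines and the fluorine cannot be drawn from this step. They also leave open whether the same exchange would stay within the scatter on a core with methyl groups in place of the chlorines, since no pair shown tests it there.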